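Cycloheptenyl in place of thiophenyl on the biphenyl-type core

This account rests on a few compounds, and the source may have more. Where it says the series, first, only, none or still open, it means among the compounds named here.

Two compounds of this series carry values in a functional assay for agonist activity at G protein-coupled receptor 88 (Homo sapiens), read by HTRF and cAMP accumulation; on this read-out lower numbers stand for an effect already at smaller amounts and higher numbers for an effect only at larger amounts of compound. Compound 1 `CCC(CC)C(N)CCN(C(=O)[C@@H]1C[C@H]1c1ccccc1)c1ccc(-c2ccccc2)cc1` gives 2 nM in this assay. Compound 2 `CC(C)C[C@H](N)CN(C(=O)[C@@H]1C[C@H]1c1ccccc1)c1ccc(-c2ccsc2)cc1` differs from compound 1 in several places. In this assay compound 2 gives 1200 nM; this is the highest of the two numbers shown, and the gap to compound 1 lies beyond the scatter. Within the data shown here, no single-change step between measured compounds is available, so the effect of the aryl group alone cannot be read from the pair.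

Compound 3 `CC(C)C[C@H](N)CN(C(=O)[C@@H]1C[C@H]1c1ccccc1)c1ccc(C2=CCCCCC2)cc1` is not yet measured. It arises from compound 2 by the change (cyclohept-1-en-1-yl in place of thiophen-3-yl on an aromatic carbon), that is, cyclohept-1-en-1-yl in place of thiophen-3-yl on an aromatic carbon, para to a large group. Nothing in the measured data speaks to a ring of this kind at that place. The expectation for compound 3 in this assay is therefore held loosely: a step of no more than moderate size, with the direction uncertain, a 2.4-fold lower number from compound 2 to compound 3 (0.38 log units; beyond the scatter). Compound 3 is expected to give about 500 nM in this assay, within a range from 60 nM to 4000 nM.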

Compound 3, half-maximal effective concentration: 2100 nM
Compound 3: the middle estimate sits 4.2-fold (0.62 log units) below what was measured; the range from low to high includes it.
By their numbers in this assay, from the lowest: compound 1; then compounds 2 and 3 (each within the scatter of the next).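

In this assay the step is a 1.8-fold higher number from compound 2 to compound 3 (0.24 log units; within the scatter) and gives the first single-change reading at this position in the compounds shown. On an aromatic carbon para to a large group, cyclohept-1-en-1-yl and thiophen-3-yl cannot be told apart, even though a seven-membered non-aromatic ring of carbon only replaces a five-membered aromatic ring with 1 hetero atom, and the hydrogen-bond acceptor count of the group goes from 1 to 0. No available measurement gives a reason for this outcome.

Compound 1 differs from compound 2 and compound 3 in several places, so the contributions of its phenyl group and of its amine-bearing chain to its value remain unseparated. Still open, from the compounds shown here alone, is how a plain phenyl group would read on the amine-bearing chain of compound 2 and compound 3, and how a saturated cycloheptyl ring, a smaller cyclopentenyl ring or a cycloheptenyl ring carrying a hydroxyl group or a carboxylic acid would read at this position.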